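Fluoro in place of methyl: compound 3 to compound 4

The compounds below may be only part of what the source reports. "The series", "measured", "known", "first", "only" and "open" are said of these compounds alone.

Measured so far in a functional assay on HepG2 cells (Homo sapiens) for inhibition, read by MTT assay, with a stated time of 48 h; a lower number here means a stronger inhibitor, a higher number a weaker inhibitor:
compound 1 `c1ccc(-c2nn(-c3ccccc3)c3nccc(-c4cccs4)c23)cc1` gives 39300 nM
compound 2 `Clc1ccc(-c2ccnc3c2c(-c2ccccc2)nn3-c2ccccc2)cc1` gives 61100 nM
compound 3 `Cc1ccc(-c2ccnc3c2c(-c2ccccc2)nn3-c2ccccc2)cc1` gives 10700 nM

Compound 3 stands lowest of the three at 10700 nM and its steps to both others lie beyond the scatter. The next change leads to compound 4 `Fc1ccc(-c2ccnc3c2c(-c2ccccc2)nn3-c2ccccc2)cc1` and counts as fluoro in place of methyl on an aromatic carbon in short: fluoro in place of methyl on an aromatic carbon, para to a large group, or 4-methylphenyl to 4-fluorophenyl. Going by the values given here, no measured step exchanges these two groups. The closest evidence is a 5.7-fold lower number from compound 2 to compound 3 (0.76 log units; beyond the scatter) for methyl in place of chloro, a modest step. The change of thiophen-2-yl to 4-methylphenyl gives a 3.7-fold lower number from compound 1 to compound 3 (0.57 log units; beyond the scatter) and is also modest. The remaining step of a 1.6-fold higher number from compound 1 to compound 2 (0.19 log units; within the scatter) leaves compound 1 and compound 2 unseparated. Among the compounds with values here, both measured departures from methyl thus end at a higher number, on only two examples. Within the data shown here, a modest step to a higher number is therefore expected in this assay for fluoro, though no fluoro compound has yet been measured to fix its size. The expected step is a 2.6-fold higher number from compound 3 to compound 4 (0.42 log units; beyond the scatter) on this estimate. For compound 4 the estimated value is 28000 nM with an expected range from 11000 nM to 70000 nM as the working figures.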

Compound 4, half-maximal inhibitory concentration: 1570 nM
The estimate for compound 4 lay 18-fold (1.25 log units) above the measured number, and the stated range ends above it.
By their numbers in this assay, from the lowest: compound 4; then compound 3; then compounds 1 and 2 (each within the scatter of the next).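

In this assay, the group para to a large group separates the two halogens sharply: a 39-fold lower number from compound 2 to compound 4 (1.59 log units; beyond the scatter) for fluoro in place of chloro, so chloro gives no guide to fluoro at this place. Fluoro in place of methyl gives a 6.8-fold lower number from compound 3 to compound 4 (0.83 log units; beyond the scatter) and is the first departure from methyl that ends at a lower number, which makes compound 4 the strongest inhibitor of the four, with its steps to all the others beyond the scatter. Against thiophen-2-yl, 4-fluorophenyl gives a 25-fold lower number from compound 1 to compound 4 (1.40 log units; beyond the scatter), a larger drop than a 3.7-fold lower number from compound 1 to compound 3 (0.57 log units; beyond the scatter) for 4-methylphenyl. Nothing at hand explains why fluoro stands apart from methyl and chloro here.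

From the compounds shown here alone, whether the lower number belongs to fluoro alone or extends to groups such as methoxy, hydroxyl, an amine or trifluoromethyl at the same place remains open. Going by these compounds, the four compounds also share the rest of the core, so it is unknown whether 4-fluorophenyl would keep its lead with another group on the core, or in cells other than those of this assay.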